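The source may report more compounds than this note shows. Statements on the series, on what has been measured and on what is new or still open speak of the compounds shown alone.

Compound 1 `CCCCCCCCCCCCn1nnc(C(NC(=O)c2ccc(Cl)cc2)c2ccccc2)n1` is the weaker of the two measured compounds in an assay on microsomes from liver for inhibition of sterol O-acyltransferase 1 (Rattus norvegicus) (a lower number here means a stronger inhibitor, a higher number a weaker inhibitor), where compound 1 gives 440 nM. Among the measured compounds shown here, its only measured neighbour is compound 2 `CCCCCCCCCCCCn1nnc(C(NC(=O)c2cccc([N+](=O)[O-])c2)c2ccccc2)n1`, which in this assay gives 80 nM; the step of a 5.5-fold lower number from compound 1 to compound 2 (0.74 log units; beyond the scatter) shows that exchanging the ring on the carbonyl carbon moves the number beyond the scatter. Compound 3 `CCCCCCCCCCCCn1nnc(C(NC(=O)c2ccccc2C(F)(F)F)c2ccccc2)n1` arises from compound 1 by the change (2-(trifluoromethyl)phenyl in place of 4-chlorophenyl on a carbonyl carbon). For the measured compounds named here, the step from compound 1 to compound 2 bears on this only as a sign that changes at this position matter; no measured compound carries a 2-(trifluoromethyl)phenyl, so its direction is not fixed by the data. The expected step of a 1.5-fold lower number from compound 1 to compound 3 (0.17 log units; within the scatter) is therefore small, with room on either side. For compound 3 the estimate in this assay is 300 nM, within a range from 80 nM to 1200 nM.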

Compound 3, half-maximal inhibitory concentration: 120 nM
Estimate against measurement, compound 3: 2.5-fold (0.40 log units) above; measured number inside the range.
By their numbers in this assay, from the lowest: compounds 2 and 3 (each within the scatter of the next); then compound 1.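

The step of a 3.7-fold lower number from compound 1 to compound 3 (0.56 log units; beyond the scatter) in this assay shows that a second, quite different replacement of the 4-chlorophenyl on the carbonyl carbon also lowers the number beyond the scatter, so the gain at this position does not depend on the 3-nitrophenyl alone. The step of a 1.5-fold higher number from compound 2 to compound 3 (0.18 log units; within the scatter) gives no order between the two replacements, and both stand apart from the 4-chlorophenyl of compound 1. Nothing available explains why these groups differ from the 4-chlorophenyl.

From the compounds shown here alone, what an amine or a carboxylic acid on this ring would do remains open, as does whether the ring itself is needed on the carbonyl carbon. The compounds shown also leave open how a shorter chain on the shared core would change the number.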